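The source may hold more compounds than are shown below. What is called first, only, known or untested is meant among the compounds shown, and "the series" means these compounds.

Compound 1 `OCCCCC#Cc1ccccc1C#Cc1ccccn1`: 25100 nM
Compound 2 `OCCCCC#Cc1ccccc1C#Cc1cccs1`: 16600 nM
Compound 3 `CSc1ccccc1C#Cc1ccccc1C#CCCCCO`: 3900 nM

In a functional assay on MDA-MB-435 cells (Homo sapiens) for cytotoxicity (on this read-out lower numbers stand for stronger inhibition of growth and higher numbers for weaker inhibition of growth), compound 2 stands second highest of the three numbers, close to compound 1 and well apart from compound 3, which gives the lowest number of the set. Compound 4 `OCCCCC#Cc1ccccc1C#Cc1cccc(O)c1` differs from compound 2 by 3-hydroxyphenyl in place of thiophen-2-yl on a triple-bonded carbon. Within the data shown here, the only measured change at the same place is a 1.5-fold lower number from compound 1 to compound 2 (0.18 log units; within the scatter), which lies within the scatter; compound 3 carries a different change and does not bear directly on this one. Among the measured compounds shown here, since the one comparable exchange moved the number little, no step beyond the scatter is expected here, with at most a slight drift downward. Compound 4 is therefore estimated at 14000 nM, with a range from 5000 nM to 40000 nM. The expected step is a 1.2-fold lower number from compound 2 to compound 4 (0.07 log units; within the scatter).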

Compound 4, concentration for 50% growth inhibition: 16100 nM
For compound 4 the middle estimate is 1.2-fold (0.06 log units) below the measured one; measured number inside the range.
By their numbers in this assay, from the lowest: compound 3; then compounds 4, 2 and 1 (each within the scatter of the next).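

In this assay, 3-hydroxyphenyl on the triple-bonded carbon gives a 1.0-fold lower number from compound 2 to compound 4 (0.01 log units; within the scatter) and a 1.6-fold lower number from compound 1 to compound 4 (0.19 log units; within the scatter) and so sits with thiophen-2-yl and pyridin-2-yl, all within the scatter. This place therefore tolerates a six-membered aromatic ring of carbon only that carries a hydrogen-bond donor, with no step beyond the scatter among these three rings. Nothing measured here explains why the numbers stay together. Still open, going by these compounds, is whether a ring bearing an amine or a carboxylic acid, or a plain alkyl chain in place of the ring, would also leave the number unmoved. Also open, on these data alone, is how the different change in compound 3 would behave with these rings.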